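This account rests on a few compounds, and the source may have more. Where it says the series, first, only, none or still open, it means among the compounds named here.

Compound 1 `COc1cccc(Cc2coc3cc(O)cc(O)c3c2=O)c1`, compound 2 `COc1ccc(Cc2coc3cc(O)cc(O)c3c2=O)cc1OC` and compound 3 `COc1ccc(Cc2coc3cc(OCCCl)cc(O)c3c2=O)cc1` share one core and were each tested in a functional assay on H9c2 cells (Mus musculus) for cytotoxicity against H9c2 (Rattus norvegicus), read by MTT assay, with a stated time of 24 h; a higher number here means that more compound is needed for the effect, a lower number that less compound is needed. In this assay compound 1 reaches only a limit, > 100000 nM. Compound 2 gives 12100 nM. Between these two lies an at least 8.2-fold lower number from compound 1 to compound 2 (0.91 log units; beyond the scatter). Compound 3 also reaches only a limit, > 100000 nM, so its standing is known as a boundary rather than as a number.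

Compound 4 `CCC(=O)Oc1cc(O)c2c(=O)c(Cc3ccc(OC)cc3)coc2c1` differs from compound 3 in one place: propanoyl in place of 2-chloroethyl on an oxygen on an aromatic ring. Among the measured compounds shown here, no measured step touches this place; the single measured step alters a different part of the molecule and therefore offers no guide to the direction or size of this change. What carries the most weight is the limit of > 100000 nM in this assay, at which 2 of the 3 values shown sit, and compound 4 is therefore expected to stay near that boundary. The expected step of a number no higher from compound 3 to compound 4 (the limit leaves the size open) is within the scatter. Compound 4 is estimated at 100000 nM, with a range from 20000 nM to 300000 nM, most likely reported once more as a limit.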

Compound 4, half-maximal effective concentration: > 100000 nM
Compound 4: no number, only a limit; the forecaster's own chance of this, stated with the estimate: 70%; the middle value lies on the limit itself.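

Compound 4, like compound 3, gives only a limit in this assay, so no step between the two can be read: the limit of > 100000 nM in this assay, at which 3 of the 4 values shown sit.

From the compounds shown here alone, whether propanoyl or 2-chloroethyl on that oxygen gives the lower number stays open, as does the actual concentration each compound needs for the effect.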